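From nitro to amino on compound 3

The compounds below may be only part of what the source reports. "The series", "measured", "known", "first", "only" and "open" are said of these compounds alone.

In a functional assay on MDA-MB-231 cells (Homo sapiens) for antiproliferative activity, read by MTT assay, with a stated time of 72 h (on this read-out higher numbers stand for weaker inhibition and lower numbers for stronger inhibition), compound 3 (`COc1ccc(OC(=O)c2cc(OC)c(OC)c(OC)c2)cc1[N+](=O)[O-]`) gives > 100000 nM as its reading, which is a limit of the assay and not a number.

Compound 4 (`COc1ccc(OC(=O)c2cc(OC)c(OC)c(OC)c2)cc1N`) keeps the rest of compound 3 and carries amino in place of nitro on an aromatic carbon, ortho to a methoxy group (amino in place of nitro on an aromatic carbon).

Within the data shown here, no measured pair isolates this change. Two other compounds carry the amino group but differ from compound 4 elsewhere in the structure. In this assay compound 1 (`COc1ccc(-n2ccnc2-c2cc(OC)c(OC)c(OC)c2)cc1N`) gives 1040 nM and compound 2 (`COc1ccc(NC(=O)c2cc(OC)c(OC)c(OC)c2)cc1N`) gives 18600 nM as measured values.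

Both of these readings are numbers, and that is the basis for expecting a large change in this assay beyond the scatter, towards lower numbers and stronger inhibition. Among the measured compounds shown here, with only three compounds measured, this remains a weak guide. Going by these compounds, the estimate amounts to an expected at least 12-fold lower number from compound 3 to compound 4 (1.09 log units; beyond the scatter) towards stronger inhibition, of a size that stays open, the starting point being only a limit. The middle of the estimate lies between the readings of the two amino compounds, and the range is kept wide. In this assay the estimated value for compound 4 is 8000 nM with an expected range of 1200 nM to 50000 nM for the coming measurement.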

Compound 4, half-maximal inhibitory concentration: > 100000 nM
Compound 4: a limit, no number (the forecaster's own chance of this, stated with the estimate: 15%); middle value at least 12-fold (1.09 log units) from the limit.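

In this assay, compound 3 and compound 4 both stand at a limit and not at a number, so no step can be read for amino in place of nitro on an aromatic carbon: the limit of > 100000 nM in this assay, at which 2 of the 4 values shown sit.

The compounds shown leave open whether this change alters the reading in this assay at all, and in which direction.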